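The compounds below may be only part of what the source reports. "The series", "measured", "known", "first", "only" and "open" are said of these compounds alone.

Compound 1 has the structure `CC1CCN(C2CCN(S(=O)(=O)c3cccc(C(F)(F)F)c3)CC2)CC1`. In an ADME assay on HCT-116 cells (Homo sapiens) for cytotoxicity, read by CellTiter-Glo, with a stated time of 72 h (on this read-out higher numbers stand for weaker inhibition and lower numbers for stronger inhibition), compound 1 gives > 5000 nM, which is a limit of the assay and not a number. Compound 2 has the structure `CC1CCN(C2CCN(S(=O)(=O)c3ccccc3-c3ccccc3)CC2)CC1`. In this assay compound 2 gives > 5000 nM, again a limit. Compound 3 has the structure `CC1CCN(C2CCN(S(=O)(=O)c3ccccc3-c3ccc(Cl)cc3)CC2)CC1`. In this assay compound 3 gives > 5000 nM, also a limit.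

The difference between the core of compound 1 and the core of compound 2 is not broken down here. Compound 2 and compound 3 differ by chloro in place of hydrogen on an aromatic carbon, and the step that the two limits leave unreadable from compound 2 to compound 3 cannot be read because of the limit of > 5000 nM in this assay, at which 3 of the 3 values shown sit.

Compound 4, with the structure `CC1CCN(C2CCN(S(=O)(=O)c3ccc(Cl)c(C(F)(F)F)c3)CC2)CC1`, has not yet been measured. It differs from compound 1 by chloro in place of hydrogen on an aromatic carbon, the same kind of change as from compound 2 to compound 3, though here the chloro sits ortho to a trifluoromethyl group. Because (the limit of > 5000 nM in this assay, at which 3 of the 3 values shown sit), compound 4 is expected to stay at the limit too, so the step that the limit leaves unreadable from compound 1 to compound 4 is an estimate only. For compound 4 the expected value in this assay is 8000 nM, within 3000 nM to 30000 nM.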

Compound 4, half-maximal inhibitory concentration: > 5000 nM
Compound 4: no number, only a limit; the forecaster's own chance of this, stated with the estimate: 85%; the middle value does not contradict the limit.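

The step from compound 1 to compound 4 cannot be read, because both compounds give a limit of the assay and not a number: the limit of > 5000 nM in this assay, at which 4 of the 4 values shown sit.

The compounds shown leave open how strongly any of them inhibits in this assay, and whether chloro in place of hydrogen on an aromatic carbon changes the read-out at all.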